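A Smaller Amide on the Shared Core

This account rests on a few compounds, and the source may have more. Where it says the series, first, only, none or still open, it means among the compounds named here.

Compound 2 `CCN(CC)C(=O)[C@@H]1CCCN(S(=O)(=O)c2ccc(S(=O)(=O)N(CC)CC)cc2)C1` in a functional assay on BXPC-3 cells (Homo sapiens) for inhibition, read by MTT assay, with a stated time of 7 days (on this read-out lower numbers stand for stronger inhibition and higher numbers for weaker inhibition), gives 10500 nM, the higher of the two numbers recorded so far. Within the data shown here, its only neighbour is compound 1 `CCN(CC)S(=O)(=O)c1ccc(S(=O)(=O)N2CCC[C@@H](C(=O)N(C)C(C)C)C2)cc1`, which in this assay gives 7700 nM. The two are separated by a 1.4-fold higher number from compound 1 to compound 2 (0.13 log units; within the scatter), a step within the scatter, and the difference between them sits on the carbonyl carbon, where the amine part of the amide is exchanged. Compound 3 `CCN(CC)S(=O)(=O)c1ccc(S(=O)(=O)N2CCC[C@@H](C(=O)NC)C2)cc1` has not yet been measured. It differs from compound 2 by methylamino in place of diethylamino on a carbonyl carbon. Among the measured compounds shown here, the one measured step that bears on this change, a 1.4-fold higher number from compound 1 to compound 2 (0.13 log units; within the scatter), also exchanges the amine on that carbonyl carbon and stayed within the scatter, so the data give no ground for expecting a large move in either direction in this assay. The expected step is therefore small: a 1.1-fold lower number from compound 2 to compound 3 (0.02 log units; within the scatter). For the measured compounds named here, the range around that expectation is kept broad, since no measured compound carries a methylamino group on that carbonyl carbon. In this assay compound 3 is estimated at 10000 nM, with a range from 3000 nM to 35000 nM.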

Compound 3, half-maximal inhibitory concentration: 13800 nM
For compound 3 the middle estimate is 1.4-fold (0.14 log units) below the measured one; low and high end bracket the measured number.
By their numbers in this assay, from the lowest: compounds 1, 2 and 3 (each within the scatter of the next).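

Compound 3 differs from the other two in carrying the amide hydrogen on the nitrogen attached to this carbonyl carbon, and its diethylamino-to-methylamino exchange is a larger cut than the one seen earlier. Even so, in this assay the change from the diethylcarbamoyl group to the methylcarbamoyl group remains a small move (a 1.3-fold higher number from compound 2 to compound 3 (0.12 log units; within the scatter)), and the comparison with the isopropyl-bearing amide also stays within the scatter (a 1.8-fold higher number from compound 1 to compound 3 (0.25 log units; within the scatter)), so across these three amides neither removing carbon from the amine part nor introducing the amide hydrogen separates the compounds on this read-out. Nothing available here offers an explanation for how little the numbers respond to this exchange.

From the compounds shown here alone, the three compounds cover only open-chain alkyl groups on this amide nitrogen, so it remains open whether a group of another kind at the same carbonyl carbon, such as a piperidine amide, a benzylamino group or a carboxylic acid in place of the amide, would also fall in this range. Going by these compounds, it is equally open whether the same insensitivity would appear if the diethylsulfonamide part of the shared core were exchanged for another amine.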